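This account rests on a few compounds, and the source may have more. Where it says the series, first, only, none or still open, it means among the compounds named here.

Measured so far in an ADME assay on HepG2 2.2.15 cells (Homo sapiens) for cytotoxicity; a lower number here means that less compound is tolerated, a higher number that more compound is tolerated

compound 1 `CCCCC(=O)OCCc1c(-c2ccccc2Cl)c2cc(Cl)ccc2[nH]c1=O` gives 200000 nM
compound 2 `COCC(=O)OCCc1c(-c2ccccc2Cl)c2cc(Cl)ccc2[nH]c1=O` gives 74000 nM
compound 3 `O=C(OCCc1c(-c2ccccc2Cl)c2cc(Cl)ccc2[nH]c1=O)C1CCCC1` gives 46000 nM

Two steps show where compound 3 stands in this small set. The step of a 1.6-fold lower number from compound 2 to compound 3 (0.21 log units; within the scatter) is too small to separate the two, whereas a 4.3-fold lower number from compound 1 to compound 3 (0.64 log units; beyond the scatter) is modest but real. Its number therefore shares the lower part of the range, and only the first compound stands clear.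

Compound 4 `O=C(OCCc1c(-c2ccccc2Cl)c2cc(Cl)ccc2[nH]c1=O)c1cccs1` differs from compound 3 in one place, with thiophen-2-yl in place of cyclopentyl on a carbonyl carbon and the rest of the molecule unchanged.

All three measured steps alter the group on this same carbonyl carbon. Besides the two above there is a 2.7-fold lower number from compound 1 to compound 2 (0.43 log units; beyond the scatter) as a further modest step. None of them places an aromatic ring there, so this swap has not been tested directly. The incoming ring is the same size as the one it replaces, and no direction can be argued from the data. In this assay a step no larger than those modest ones is expected, most likely none beyond the scatter. The estimate amounts to a 1.2-fold higher number from compound 3 to compound 4 (0.08 log units; within the scatter) as the expected step. For compound 4 the estimated value is 55000 nM with an expected range from 22000 nM to 130000 nM in repeated measurements.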

Compound 4, half-maximal cytotoxic concentration: > 1700000 nM
Compound 4 was reported as a limit; the forecaster's own chance of this, stated with the estimate: 10%; middle value at least 30-fold (1.49 log units) away from the limit.
By their numbers in this assay, from the lowest: compounds 3 and 2 (each within the scatter of the next); then compound 1. At a limit, above all of these: compound 4.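

In this assay compound 4 gives > 1700000 nM, which is a limit of the assay and not a number. Replacing cyclopentyl with thiophen-2-yl keeps the same count of heavy atoms and a five-membered ring, yet it gives an at least 36-fold higher number from compound 3 to compound 4 (1.56 log units; beyond the scatter), so this position can shift the tolerated amount far more than the earlier modest steps suggested, and ring size alone does not settle the outcome. Going by these compounds alone, the other two groups on this carbonyl carbon also give way to thiophen-2-yl, with an at least 22-fold higher number from compound 2 to compound 4 (1.36 log units; beyond the scatter) and an at least 8.5-fold higher number from compound 1 to compound 4 (0.92 log units; beyond the scatter), which makes the aromatic ring the only group here that reaches the limit: the limit of > 1700000 nM in this assay, at which 1 of the 4 values shown sits.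

The compounds shown leave open whether this result belongs to thiophen-2-yl alone or to aromatic rings on this carbonyl carbon more widely, and a phenyl ring or a furan-2-yl ring in the same place would help separate the two. How far compound 4 truly lies from the others also stays open, and nothing here explains why the change has so large an effect.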